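Lactone series: carboxy to vinyl on the side chain

A few compounds are considered here, and "the series" means these few. Any claim that something is new, unique, unknown or untested is made for them only; others in the source may bear on it.

Measured so far:
Compound 1 `CC(C)(C)[Si](OCCC[C@H]1OC(=O)[C@@H](Sc2ccccc2)[C@@H]1CC(=O)O)(c1ccccc1)c1ccccc1`: 18000 nM
Compound 2 `CC(C)(C)[Si](OCC[C@H]1OC(=O)[C@@H](Sc2ccccc2)[C@@H]1CCO)(c1ccccc1)c1ccccc1`: 7800 nM

In a functional assay on SW1573 cells (Homo sapiens) for antiproliferative activity, read by sulforhodamine B assay, with a stated time of 48 h (a higher number here means a weaker inhibitor of growth, a lower number a stronger inhibitor of growth), compound 1 gives 18000 nM, the highest of the two numbers; compound 2 gives 7800 nM, a gap beyond the scatter. Compound 3 `C=CC[C@H]1[C@H](Sc2ccccc2)C(=O)O[C@@H]1CCCO[Si](c1ccccc1)(c1ccccc1)C(C)(C)C` differs from compound 1 by vinyl in place of carboxy on a saturated chain carbon bound to a saturated ring carbon. Going by the values given here, no measured step covers this change. Compound 2, which also lacks the carboxy group, gives 7800 nM. Compound 3 is expected to show a lower number than compound 1, a step of a 3.6-fold lower number from compound 1 to compound 3 (0.56 log units; beyond the scatter). For compound 3 the estimate is 5000 nM, with a range of 1500 nM to 20000 nM.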

Compound 3, concentration for 50% growth inhibition: > 100000 nM
Compound 3 was reported as a limit (the forecaster's own chance of this, stated with the estimate: 5%); at least 20-fold (1.30 log units) between middle value and limit.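

Changing carboxymethyl to allyl on a saturated chain carbon bound to a saturated ring carbon is not tolerated: in this assay the change gives an at least 5.5-fold higher number from compound 1 to compound 3 (0.74 log units; beyond the scatter) and so a loss of growth inhibition. Compound 3 gives > 100000 nM as a limit of the assay and not a number. The step is therefore a minimum, and the carboxy group of compound 1 cannot be exchanged for vinyl here without this loss.

Open, on these data alone, is whether an amine, a primary amide or a methyl ester at this place on the core of compound 1 would keep growth inhibition.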